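Working notes: methylcarbamoyl to ethyl on compound 2

A few compounds are considered here, and "the series" means these few. Any claim that something is new, unique, unknown or untested is made for them only; others in the source may bear on it.

Measured so far (an ADME assay on TZM cells (Homo sapiens) for cytotoxicity, with a stated time of 1 days; a lower number here means that less compound is tolerated, a higher number that more compound is tolerated)
- compound 1 `Cc1cc(CCC#N)cc(C)c1Oc1cc(Nc2ccc(C#N)cc2)c(N)cc1C(=O)NC(C)C` gives 184000 nM
- compound 2 `CNC(=O)OCc1cc(N)c(Nc2ccc(C#N)cc2)cc1Oc1c(C)cc(CCC#N)cc1C` gives 46800 nM

Among the measured compounds shown here, compound 2 holds the lower of the two numbers (46800 nM) and has compound 1 as its only measured neighbour. Compound 3 (`CCOCc1cc(N)c(Nc2ccc(C#N)cc2)cc1Oc1c(C)cc(CCC#N)cc1C`) is still to be measured. It carries ethyl in place of methylcarbamoyl on an oxygen on a saturated carbon, which turns ((methylcarbamoyl)oxy)methyl into ethoxymethyl.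

For the measured compounds named here, only one measured step bears on this change, and it involves the same group: a 3.9-fold lower number from compound 1 to compound 2 (0.59 log units; beyond the scatter) (modest). That step exchanged isopropylcarbamoyl for ((methylcarbamoyl)oxy)methyl. Going by the values given here, no measured step removes methylcarbamoyl alone, so the data give no direction for the new change. No step beyond the scatter is therefore expected in this assay, although a step of similar modest size in either direction would fit the little that is known. The expected change is a 1.1-fold lower number from compound 2 to compound 3 (0.05 log units; within the scatter) (an estimate). For compound 3 the estimated value is 42000 nM (expected range 15000 nM to 120000 nM).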

Compound 3, half-maximal cytotoxic concentration: 194000 nM
Compound 3: middle estimate off by 4.6-fold (0.66 log units), on the low side; measured number outside the range, above it.
By their numbers in this assay, from the lowest: compound 2; then compounds 1 and 3 (each within the scatter of the next).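

In this assay, ethyl in place of methylcarbamoyl on the oxygen gives a 4.1-fold higher number from compound 2 to compound 3 (0.62 log units; beyond the scatter), so the low number of compound 2 does not persist once methylcarbamoyl leaves, even though ethoxymethyl keeps the oxygen on a saturated carbon. The aromatic carbon now carries three different groups across the series, and ethoxymethyl and isopropylcarbamoyl read alike, with a 1.1-fold higher number from compound 1 to compound 3 (0.02 log units; within the scatter), leaving ((methylcarbamoyl)oxy)methyl as the only one of the three with a step beyond the scatter to both others. Nothing available on these compounds accounts for this difference.

As far as these compounds go, it remains open whether a hydroxymethyl group, a longer ether chain such as propoxymethyl, or an amine on the same carbon would read with compound 1 and compound 3 or with compound 2. With compound 2 as the only compound shown carrying methylcarbamoyl, it also remains open whether the same exchange would give a step of this size on a different core.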